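The source may report more compounds than this note shows. Statements on the series, on what has been measured and on what is new or still open speak of the compounds shown alone.

Measured so far:
compound 1, `Nc1cccc(/C=C/c2cccc(O)c2)c1`, 43 ug/mL
compound 2, `COc1cccc(/C=C/c2cccc(O)c2)c1`, 11.5 ug/mL
compound 3, `Nc1ccc(/C=C/c2cccc(O)c2)cc1`, 42 ug/mL

These values come from a functional assay on HT-29 cells (Homo sapiens) for inhibition, read by MTT assay, with a stated time of 2 days; on this read-out higher numbers stand for weaker inhibition and lower numbers for stronger inhibition. Compound 1 and compound 2 differ by methoxy in place of amino on an aromatic carbon, and that change gave a 3.7-fold lower number from compound 1 to compound 2 (0.57 log units; beyond the scatter). Compound 3 shares its atoms with compound 1 but joins them differently; the difference between the two cores is not broken down here, and their two values lie within the scatter of each other. Compound 4, `COc1ccc(/C=C/c2cccc(O)c2)cc1`, is not yet measured. It differs from compound 3 by methoxy in place of amino on an aromatic carbon, the same kind of change as from compound 1 to compound 2, though here the methoxy sits para to a group of 9 heavy atoms rather than meta to it. Because compound 1 to compound 2 gave a 3.7-fold lower number from compound 1 to compound 2 (0.57 log units; beyond the scatter), a step of similar size, a 3.5-fold lower number from compound 3 to compound 4 (0.54 log units; beyond the scatter), is expected in this assay. Compound 4 is therefore estimated at 12 ug/mL, between 6 ug/mL and 28 ug/mL.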

Compound 4, half-maximal inhibitory concentration: 22 ug/mL
Estimate against measurement, compound 4: 1.8-fold (0.26 log units) below; the range from low to high includes it.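

In this assay, putting methoxy in place of amino gives a 1.9-fold lower number from compound 3 to compound 4 (0.28 log units; within the scatter), so this step alone cannot be told apart from repeat-measurement noise. Set beside the earlier step, its size shows no real difference: the same change on two cores in this assay, a 3.7-fold lower number (0.57 log units; beyond the scatter) from compound 1 to compound 2 and a 1.9-fold lower number (0.28 log units; within the scatter) from compound 3 to compound 4, 2.0-fold (0.29 log units) apart, within the scatter of two such steps. The change is therefore compatible with carrying over between these two cores, but two pairs cannot fix a single size for it or show how it would behave on any other core.

The compounds shown carry only amino or methoxy at the changing place, and the rest of each molecule stays the same. As far as these compounds go, whether ethoxy, a carboxylic acid or a fluorine would follow the same trend remains open.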